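Bromine for Chlorine on a Dimethoxyphenyl Benzothiazole

The compounds below may be only part of what the source reports. "The series", "measured", "known", "first", "only" and "open" are said of these compounds alone.

Of the compounds shown here, three of one benzothiazole series have been measured in a functional assay on MCF7 cells (Homo sapiens) for inhibition; a higher number here means a weaker inhibitor, a lower number a stronger inhibitor. Compound 1 `Oc1ccc(-c2nc3ccc(Cl)cc3s2)cc1` gives 26500 nM there. Compound 2 `Oc1ccc(-c2nc3ccc(Br)cc3s2)cc1` differs from it by bromo in place of chloro on an aromatic carbon and gives 4160 nM, so that this single exchange produces a 6.4-fold lower number from compound 1 to compound 2 (0.80 log units; beyond the scatter). Compound 3 `COc1ccc(-c2nc3cc(Cl)ccc3s2)cc1OC` carries a different core; how its core differs from that of compound 1 is not broken down here. In this assay compound 3 gives 27900 nM, a number close to that of compound 1 and well apart from that of compound 2.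

The unmeasured compound 4 `COc1ccc(-c2nc3cc(Br)ccc3s2)cc1OC` is built from compound 3 by bromo in place of chloro on an aromatic carbon. Among the measured compounds shown here, this is the same change as the one made from compound 1 to compound 2, and it occurs twice among the four compounds. For the measured compounds named here, the step it made in the measured pair is the only guide available, and it rests on one pair only. Compound 4 is therefore expected to show a 5.1-fold lower number from compound 3 to compound 4 (0.71 log units; beyond the scatter), a step of about the same size as the earlier one, because compound 3 starts from 27900 nM and the same exchange gave a 6.4-fold lower number from compound 1 to compound 2 (0.80 log units; beyond the scatter) on the other core. The estimate for compound 4 in this assay is 5500 nM. Given that a single precedent carries the expectation, compound 4 is estimated to fall between 2200 nM and 14000 nM.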

Compound 4, half-maximal inhibitory concentration: 13600 nM
For compound 4 the middle estimate is 2.5-fold (0.39 log units) below the measured one; measured number inside the range.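

In this assay the exchange of bromo for chloro moves the number in the same direction on the second core, with a 2.1-fold lower number from compound 3 to compound 4 (0.31 log units; beyond the scatter), but the size of the step does not carry over, and the two steps differ by more than the scatter allows: the same change on two cores in this assay, a 6.4-fold lower number (0.80 log units; beyond the scatter) from compound 1 to compound 2 and a 2.1-fold lower number (0.31 log units; beyond the scatter) from compound 3 to compound 4, 3.1-fold (0.49 log units) apart, beyond the scatter of two such steps. Across these two pairs, then, the direction of the change holds, whereas a step measured on one core gives only a rough guide to its size on the other. The two pairs do not show which feature of the cores sets the size of the step, as the cores differ in more than one place, and two pairs cannot establish a rule for the series or show that the direction would hold on a third core.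

The compounds shown leave open whether iodo, fluoro or an amine at the same aromatic carbon would extend the trend from chloro to bromo, or break it. They also leave open how much of the gap between the two steps would remain if the cores were changed one place at a time, for example with a single methoxy group.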